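The source may hold more compounds than are shown below. What is called first, only, known or untested is meant among the compounds shown, and "the series" means these compounds.

The compounds share one core, seen in compound 1 `O=C1c2c[n+]([O-])c3ccccc3c2C(=O)c2c1c1ccccc1n2Cc1cn(C[C@@H](O)CO)nn1`, which carries a triazole-bearing chain on an aromatic nitrogen. In a functional assay on A-375 cells (Homo sapiens) for cytotoxicity, read by MTT assay, with a stated time of 72 h (a higher number here means a weaker inhibitor, a lower number a stronger inhibitor), compound 1 gives 140 nM, the second highest of the three numbers measured. For the measured compounds named here, compound 2 `O=C1c2c[n+]([O-])c3ccccc3c2C(=O)c2c1c1ccccc1n2Cc1cn([C@@H]2C[C@H](O)[C@@H](CO)O2)nn1` gives 20 nM, and the single measured step, a 7.0-fold lower number from compound 1 to compound 2 (0.85 log units; beyond the scatter), shows that exchanging the chain on the triazole nitrogen alone can move the number well beyond the scatter. Compound 3 `CCCCN1CCN(CCCCn2c3c(c4ccccc42)C(=O)c2c[n+]([O-])c4ccccc4c2C3=O)CC1` gives 2150 nM, the highest number of the three, and its chain on the aromatic nitrogen holds a piperazine rather than a triazole.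

Compound 4 `CN1CCN(CCCCn2c3c(c4ccccc42)C(=O)c2c[n+]([O-])c4ccccc4c2C3=O)CC1` has not yet been measured. It differs from compound 1 as follows: 3-(4-methylpiperazin-1-yl)propyl in place of 1-(2,3-dihydroxypropyl)-1H-1,2,3-triazol-4-yl on a saturated chain carbon bound to an aromatic nitrogen. Going by the values given here, no measured step covers this exact change, so the prediction rests on compound 3, whose value 2150 nM is the only one for a piperazine-bearing chain on the core. Compound 4 is therefore expected to move toward that region, an estimated step of an 11-fold higher number from compound 1 to compound 4 (1.03 log units; beyond the scatter). The estimate for compound 4 is 1500 nM, with a likely range from 400 nM to 5000 nM.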

Compound 4, half-maximal inhibitory concentration: 30 nM
Compound 4: middle estimate off by 50-fold (1.70 log units), on the high side; the measured number lies below the stated range.
By their numbers in this assay, from the lowest: compounds 2 and 4 (each within the scatter of the next); then compound 1; then compound 3.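

In this assay, a piperazine-bearing chain on the aromatic nitrogen need not give a high number: hydrogen in place of propyl on a saturated chain carbon bound to an amine nitrogen in a ring gives a large step (a 72-fold lower number from compound 3 to compound 4 (1.86 log units; beyond the scatter)). A change of only this kind, well away from the shared core, can therefore outweigh the change from triazole to piperazine. That second change also lowers the number (a 4.7-fold lower number from compound 1 to compound 4 (0.67 log units; beyond the scatter)), so the triazole is not needed for a low number, and nothing measured here gives a reason for either step.

With only two groups shown on the ring amine nitrogen, it remains open how an ethyl group there would read. From the compounds shown here alone, a morpholine ring in place of the piperazine, or a shorter chain to the aromatic nitrogen, also remains untested by these compounds.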